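The source may hold more compounds than are shown below. What is called first, only, known or untested is meant among the compounds shown, and "the series" means these compounds.

In an ADME assay on HepG2 cells (Homo sapiens) for cytotoxicity, read by luminescence, CellTiter-Glo and ATP content, with a stated time of 72 h (on this read-out lower numbers stand for an effect already at smaller amounts and higher numbers for an effect only at larger amounts of compound), compound 1 `COc1ccc(Oc2ccc3c(NCCCNCc4cc(F)ccc4OC)ccnc3c2)cc1` gives 7000 nM, compound 2 `COc1ccc(F)cc1CNCCCNc1ccnc2cc(-c3ccc(F)cc3)ccc12` gives 770 nM and compound 3 `COc1ccc(F)cc1CNCCCNc1ccnc2cc(Oc3cccc(N(C)C)c3)ccc12` gives 3300 nM, so compound 3 holds the middle place of the three. Compound 4 `COc1ccc(F)cc1CNCCCNc1ccnc2cc(Oc3ccc(C(C)(C)C)cc3)ccc12` differs from compound 3 in one place: 4-(tert-butyl)phenyl in place of 3-(dimethylamino)phenyl on an oxygen on an aromatic ring. Going by the values given here, the closest precedent is a 2.1-fold lower number from compound 1 to compound 3 (0.33 log units; beyond the scatter), a modest exchange of one group for another on the same oxygen. The steps of a 9.1-fold lower number from compound 1 to compound 2 (0.96 log units; beyond the scatter) and a 4.3-fold higher number from compound 2 to compound 3 (0.63 log units; beyond the scatter) bear less directly, since each swaps an oxygen-linked group for 4-fluorophenyl or back. The estimated step is therefore small and slightly downward: a 1.3-fold lower number from compound 3 to compound 4 (0.10 log units; within the scatter). Compound 4 is expected at 2600 nM, with an estimated range from 1000 nM to 6500 nM.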

Compound 4, half-maximal effective concentration: 7200 nM
Beside the measured number, compound 4's estimate is 2.8-fold (0.44 log units) below it, and the stated range ends below it.
By their numbers in this assay, from the lowest: compound 2; then compound 3; then compounds 1 and 4 (each within the scatter of the next).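

In this assay the exchange on this oxygen gives a 2.2-fold higher number from compound 3 to compound 4 (0.34 log units; beyond the scatter) and so moves upward, the opposite direction to a 2.1-fold lower number from compound 1 to compound 3 (0.33 log units; beyond the scatter) at the same place. With tert-butyl in place of methoxy on the aromatic carbon, the result is a 1.0-fold higher number from compound 1 to compound 4 (0.01 log units; within the scatter) and no real shift, whereas a 9.4-fold higher number from compound 2 to compound 4 (0.97 log units; beyond the scatter) keeps the directly attached 4-fluorophenyl of compound 2 well apart from this oxygen-linked group. No measurement given here accounts for these shifts.

Going by these compounds, the step from compound 3 changes both the group and its ring place at once, so their separate contributions remain open. On these data alone, a carboxylic acid or a morpholine on the same phenyl ring also remains unexplored in these compounds.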